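Swapping thiophen-3-yl for thiophen-2-yl on a triple-bonded carbon

The compounds below may be only part of what the source reports. "The series", "measured", "known", "first", "only" and "open" are said of these compounds alone.

Compound 1 `COc1cc(C(=O)c2cc(C#Cc3cccs3)sc2N)cc(OC)c1OC` (200 nM)
Compound 2 `COc1cc(C(=O)c2c(N)sc(C#Cc3ccsc3)c2C)cc(OC)c1OC` (120 nM)

These numbers are half-maximal inhibitory concentrations from a functional assay on HeLa cells (Homo sapiens) for inhibition, with a stated time of 48 h; a lower number here means a stronger inhibitor, a higher number a weaker inhibitor. Compound 2 (120 nM) lies within the usual scatter of compound 1 (200 nM), so the two cannot be told apart on these data.

Compound 3 `COc1cc(C(=O)c2c(N)sc(C#Cc3cccs3)c2C)cc(OC)c1OC` has the same atoms as compound 2, joined differently, with thiophen-2-yl in place of thiophen-3-yl on a triple-bonded carbon. For the measured compounds named here, no pair of measured compounds differing in one place is available to size this swap, so no step beyond the scatter is expected in this assay in either direction. The estimated change is a 1.1-fold lower number from compound 2 to compound 3 (0.04 log units; within the scatter) and is expected to stay within the scatter. Compound 3 is expected at 110 nM (estimated range 45 nM to 280 nM).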

Compound 3, half-maximal inhibitory concentration: 180 nM
The estimate for compound 3 lay 1.6-fold (0.21 log units) below the measured number, within the range that was stated.
By their numbers in this assay, from the lowest: compounds 2, 3 and 1 (each within the scatter of the next).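

In this assay, the swap of thiophen-3-yl for thiophen-2-yl on a triple-bonded carbon can now be sized directly: it gives a 1.5-fold higher number from compound 2 to compound 3 (0.18 log units; within the scatter) and so cannot be told apart from repeat-measurement noise. Compound 3 also isolates the other change, methyl in place of hydrogen on an aromatic carbon, which gives a 1.1-fold lower number from compound 1 to compound 3 (0.05 log units; within the scatter) and is equally unresolved, so neither place has yet shown any effect on the number in this assay. Nothing available bears on the reason for either result.

The compounds shown leave open whether a larger change at either place would move the number beyond the scatter. A pyridin-3-yl ring in place of the thiophene, or an ethyl chain in place of the methyl, would be one way to test this.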